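The compounds below may be only part of what the source reports. "The series", "measured", "known", "first", "only" and "open" are said of these compounds alone.

Compound 1 `O=Cc1ccc(-c2cn3ccnc3c(-c3ccc4ncn(C5CCCCC5)c4c3)n2)cc1`: 25.3% in a functional assay on NCI-H522 cells (Homo sapiens) for inhibition, read by sulforhodamine B assay, with a stated time of 48 h, tested at 10 uM; on this read-out higher numbers stand for more inhibition at the one concentration tested (going by the name of the read-out) and lower numbers for less inhibition
Compound 2 `COc1ccccc1-c1cn2ccnc2c(-c2ccc3ncn(C4CCCCC4)c3c2)n1`: 22.2% in this assay

Compound 1 stands first of the two numbers shown, but only by a number 3.1 percentage points lower from compound 1 to compound 2 (within the scatter), which is within the scatter, so the two compounds are not told apart. Compound 3 `O=Cc1ccc(-c2cn3ccnc3c(-c3ccc4ncn(Cc5ccccc5)c4c3)n2)cc1` differs from compound 1 by benzyl in place of cyclohexyl on an aromatic nitrogen. Within the data shown here, the one measured step altered a different group on the shared core and does not bear on this change; no measured step tests the group on the ring nitrogen. The expectation is therefore no step beyond the scatter, a number 1.3 percentage points lower from compound 1 to compound 3 (within the scatter), with a wide range. Compound 3 is estimated at 24%, between 5% and 50%.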

Compound 3, a percentage reported as inhibition, at one concentration (the size of the read-out at that concentration, not a potency): 25.3%
Compound 3: the middle estimate sits 1.3 percentage points below what was measured; low and high end bracket the measured number.
By their numbers in this assay, from the lowest: compounds 2, 1 and 3 (each within the scatter of the next).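

Among these compounds, this is the first measured step at the aromatic nitrogen. In this assay, benzyl in place of cyclohexyl gives no change at the digits printed from compound 1 to compound 3 (within the scatter), so an aromatic ring and a non-aromatic ring of carbon cannot be told apart at this position. Nothing measured here offers an explanation for this result.

Still open, on these data alone, is whether a different group on this nitrogen, such as a longer chain ending in an amine or a carboxylic acid, would change the reading. As far as these compounds go, it is also open whether benzyl and cyclohexyl would match with 2-methoxyphenyl on the shared core.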